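The source may report more compounds than this note shows. Statements on the series, on what has been measured and on what is new or still open speak of the compounds shown alone.

Measured compounds:
Compound 1 `CCCSc1nc(Cl)c2c(n1)N(Cc1ccccc1)C(C(=O)N1CCN(C(=O)OC(C)(C)C)CC1)N2` gives 29000 nM in a functional assay on A549 cells (Homo sapiens) for antiproliferative activity, read by MTT assay, with a stated time of 72 h; on this read-out higher numbers stand for weaker inhibition and lower numbers for stronger inhibition.
Compound 2 `CCCSc1nc(Cl)c2c(n1)N(Cc1cccs1)C(C(=O)N1CCN(C)CC1)N2` gives 6420 nM in this assay.
Compound 3 `CCCSc1nc(Cl)c2c(n1)N(Cc1ccccc1)C(C(=O)NCCNC(=O)OC(C)(C)C)N2` gives 53200 nM in this assay.

Of these three numbers, compound 3 has the highest. Its nearest neighbour is compound 1, whose number lies within the scatter of repeated measurements, so the two cannot be told apart on this evidence. Compound 2 stands well beyond the scatter from compound 3, with a clearly lower number in this assay.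

The next compound, compound 4 `CCCSc1nc(Cl)c2c(n1)N(Cc1ccccc1)C(C(=O)N1CCN(C)CC1)N2`, shares the core of compound 3 and differs in one place: 4-methylpiperazin-1-yl in place of (2-((tert-butoxycarbonyl)amino)ethyl)amino on a carbonyl carbon. The group that enters is the same one that compound 2 carries on its carbonyl carbon, while compound 4 keeps the benzyl group of compound 3 and compound 1. Among the measured compounds shown here, no directly comparable step between measured compounds exists, so the expectation rests on what compound 2 shows with 6420 nM against the higher numbers of compound 1 and compound 3.

On that basis, compound 4 is expected to give a lower number than compound 3, with a step of a 5.3-fold lower number from compound 3 to compound 4 (0.73 log units; beyond the scatter) that goes beyond the scatter. The estimate for compound 4 in this assay is 10000 nM, within a range from 3500 nM to 30000 nM.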

Compound 4, half-maximal inhibitory concentration: 2800 nM
Compound 4: middle estimate off by 3.6-fold (0.55 log units), on the high side; the whole stated range lies above it.
By their numbers in this assay, from the lowest: compound 4; then compound 2; then compounds 1 and 3 (each within the scatter of the next).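

In this assay, the step at the carbonyl carbon, with 4-methylpiperazin-1-yl in place of (2-((tert-butoxycarbonyl)amino)ethyl)amino, is large, at a 19-fold lower number from compound 3 to compound 4 (1.28 log units; beyond the scatter), and the piperazine ring alone does not secure it: with the benzyl group kept, methyl in place of tert-butoxycarbonyl on an amine nitrogen in a ring gives a 10-fold lower number from compound 1 to compound 4 (1.02 log units; beyond the scatter). Phenyl in place of thiophen-2-yl, with 4-methylpiperazin-1-yl kept, gives a modest step of a 2.3-fold lower number from compound 2 to compound 4 (0.36 log units; beyond the scatter), which is still beyond the scatter and makes compound 4 the most potent of the four compounds in this assay. No supporting measurement is available to explain any of these steps.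

The step to compound 4 from compound 3 replaces an open chain with a ring and also removes tert-butoxycarbonyl, so the compounds shown do not separate these two changes. They also leave open how the number would respond to a morpholin-4-yl group on the carbonyl carbon, or to a hydrogen or an ethyl group in place of methyl on the ring amine nitrogen.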